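Benzofuran-2-yl replacing methoxyphenyl on the shared core

This account rests on a few compounds, and the source may have more. Where it says the series, first, only, none or still open, it means among the compounds named here.

Measured compounds and their values in a functional assay on MCF7 cells (Homo sapiens) for antiproliferative activity; a higher number here means a weaker inhibitor, a lower number a stronger inhibitor:
- compound 1, `C/C(=N\Nc1nc(-c2ccc(Br)cc2)cs1)c1cc2ccccc2o1`, compound 1 gives 33200 nM
- compound 2, `C/C(=N\Nc1nc(-c2ccc(Cl)cc2)cs1)c1cc2ccccc2o1`, compound 2 gives 29900 nM
- compound 3, `COc1ccc(-c2csc(N/N=C(\C)c3cc4ccccc4o3)n2)cc1`, compound 3 gives 18900 nM

The three measured compounds differ only in the group on the phenyl ring attached to the shared core. Each measured step stays within the scatter: a 1.1-fold lower number from compound 1 to compound 2 (0.05 log units; within the scatter), a 1.8-fold lower number from compound 1 to compound 3 (0.24 log units; within the scatter), and a 1.6-fold lower number from compound 2 to compound 3 (0.20 log units; within the scatter). Compound 3 therefore cannot be separated from compound 1 or compound 2 on these numbers.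

Compound 4, `C/C(=N\Nc1nc(-c2cc3ccccc3o2)cs1)c1cc2ccccc2o1`, is not yet measured. Its change from compound 3 is 1-benzofuran-2-yl in place of 4-methoxyphenyl on an aromatic carbon. For the measured compounds named here, none of the measured steps bears directly on this change, since each of them swaps one small group on the phenyl ring for another, and all three of those swaps lie within the scatter. On that basis no step beyond the scatter in this assay is expected from compound 3 to compound 4, but the uncertainty is wide. Compound 4 is estimated at 20000 nM, with a range from 6000 nM to 65000 nM, which means an expected step of a 1.1-fold higher number from compound 3 to compound 4 (0.02 log units; within the scatter).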

Compound 4, half-maximal inhibitory concentration: 25600 nM
The estimate for compound 4 lay 1.3-fold (0.11 log units) below the measured number, within the range that was stated.
By their numbers in this assay, from the lowest: compounds 3, 4, 2 and 1 (each within the scatter of the next).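

Swapping the whole 4-substituted phenyl group for 1-benzofuran-2-yl, which brings a five-membered aromatic ring with a hetero atom alongside a six-membered one, gives no step beyond the scatter in this assay against any of the three phenyl compounds (a 1.4-fold higher number from compound 3 to compound 4 (0.13 log units; within the scatter)) (a 1.2-fold lower number from compound 2 to compound 4 (0.07 log units; within the scatter)) (a 1.3-fold lower number from compound 1 to compound 4 (0.11 log units; within the scatter)). The earlier compounds shown here varied only a small group on the phenyl ring, whereas this result shows that replacing the ring itself at this aromatic carbon also leaves the number within the scatter of the other three. No supporting measurement is available that could explain this result.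

The compounds shown leave open whether an amine or a carboxylic acid on the phenyl ring would shift the number beyond the scatter. They also leave open whether a saturated ring such as piperidine at this position would do so.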